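The compounds below may be only part of what the source reports. "The series", "measured", "known", "first", "only" and "open" are said of these compounds alone.

Measured compounds in an assay on a protein complex for inhibition of CDK8/Cyclin C (Homo sapiens), with a stated time of 1 h; a higher number here means a weaker inhibitor, a lower number a stronger inhibitor:
compound 1 `O=C(O)/C=C/c1ccncc1-c1ccc2cc[nH]c2c1` gives 2.4 nM;
compound 2 `NC(=O)/C=C/c1ccncc1-c1ccc2ccccc2c1` gives 10.5 nM;
compound 3 `Cn1ncc2cc(-c3cnccc3/C=C/C(=O)N3CCOCC3)ccc21` gives 356 nM.

Among these three numbers compound 2 holds the second highest. Its nearest neighbour is compound 1, whose number is lower by a margin beyond the usual scatter, while compound 3 lies far higher, also beyond the scatter. The account now turns to compound 4 `CNC(=O)/C=C/c1ccncc1-c1ccc2ccccc2c1`, which has not yet been measured. It differs from compound 2 in one place: methyl in place of hydrogen on an amide-type nitrogen. For the measured compounds named here, no pair of measured compounds shows this same change, so no step of this exact kind is at hand. The change is small, and only a modest weakening is expected in this assay, near the edge of the scatter. Compound 4 is therefore estimated at 20 nM, with a range from 6 nM to 70 nM. The expected step is a 1.9-fold higher number from compound 2 to compound 4 (0.28 log units; within the scatter).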

Compound 4, half-maximal inhibitory concentration: 12.4 nM
The estimate for compound 4 lay 1.6-fold (0.21 log units) above the measured number; low and high end bracket the measured number.
By their numbers in this assay, from the lowest: compound 1; then compounds 2 and 4 (each within the scatter of the next); then compound 3.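

In this assay, methyl in place of hydrogen on the amide-type nitrogen gives a 1.2-fold higher number from compound 2 to compound 4 (0.07 log units; within the scatter) and this step lies within the scatter, so compound 2 and compound 4 cannot be told apart. For the compounds shown here, this is the first comparison here of compounds that differ in one place, and it shows that this nitrogen can carry a methyl with no change beyond the scatter. Nothing at hand bears on why this is so. On these data alone, whether the same holds for a longer chain such as ethyl or propyl on this nitrogen stays open. So does whether a second methyl on it would be tolerated.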